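Moving a trifluoromethyl group around a phenyl ring

The source may report more compounds than this note shows. Statements on the series, on what has been measured and on what is new or still open speak of the compounds shown alone.

In a functional assay on MDA-MB-231 cells (Homo sapiens) for antiproliferative activity, read by MTT assay, with a stated time of 48 h (on this read-out higher numbers stand for weaker inhibition and lower numbers for stronger inhibition), three related compounds have been measured so far. Compound 1 (`COC(=O)/C(=C/c1ccccc1)CN1C(=O)[C@@H](OC)[C@H]1c1ccccc1C(F)(F)F`) gives 17600 nM. Compound 2 (`COc1ccc(OC)c([C@@H]2[C@H](OC)C(=O)N2C/C(C#N)=C/c2ccccc2)c1`) gives 23400 nM, which lies within the usual scatter of compound 1. Compound 3 (`CCOC(=O)/C(=C/c1ccccc1)CN1C(=O)[C@@H](OC)[C@H]1c1ccccc1Br`) gives 6860 nM, a lower number than compound 1 by more than the scatter, and so stronger inhibition. Compound 1 therefore stands level with compound 2 and on the weaker side of compound 3.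

The next compound is compound 4 (`COC(=O)/C(=C/c1ccccc1)CN1C(=O)[C@@H](OC)[C@H]1c1cccc(C(F)(F)F)c1`), which has the same atoms as compound 1, joined differently: 3-(trifluoromethyl)phenyl in place of 2-(trifluoromethyl)phenyl on a saturated ring carbon. Here 3-(trifluoromethyl)phenyl takes the place of 2-(trifluoromethyl)phenyl on a saturated ring carbon, and the rest of the molecule stays the same.

Among the measured compounds shown here, no two measured compounds differ in only one place, so the data do not show directly how this assay responds to such a shift. The best anchor is compound 1 itself, at 17600 nM, and no step beyond the scatter is expected. The estimated change is small: a 1.1-fold lower number from compound 1 to compound 4 (0.04 log units; within the scatter). For compound 4 the estimated value is 16000 nM, with an expected range of 7000 nM to 35000 nM.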

Compound 4, half-maximal inhibitory concentration: 18200 nM
Compound 4: the middle estimate sits 1.1-fold (0.06 log units) below what was measured; the measured number falls inside the stated range.
By their numbers in this assay, from the lowest: compound 3; then compounds 1, 4 and 2 (each within the scatter of the next).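

Moving the trifluoromethyl group, with 3-(trifluoromethyl)phenyl in place of 2-(trifluoromethyl)phenyl on a saturated ring carbon, gives the first step here that can be read in one place: a 1.0-fold higher number from compound 1 to compound 4 (0.01 log units; within the scatter) in this assay, which lies within the scatter. For this pair, then, the two placements of the group on the phenyl ring stand level, and the read-out does not tell them apart, although the atoms are the same and only their arrangement differs. The compounds shown offer no measured evidence on why these two placements read alike.

Among the compounds shown here, still open is whether this position tolerates other groups equally well, for instance a phenyl ring carrying an amine or a carboxylic acid instead of trifluoromethyl, since this step covers only one group moved between two places on the ring. For the compounds shown here, compound 3 also remains unexplained, as no step joins it to another compound through a difference in just one place, so its number cannot yet be tied to any single part of the molecule.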